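The compounds below may be only part of what the source reports. "The series", "measured", "known", "first", "only" and "open" are said of these compounds alone.

Measured so far in a functional assay on HBL-100 cells (Homo sapiens) for inhibition, read by sulforhodamine B assay, with a stated time of 48 h; a lower number here means a stronger inhibitor of growth, a higher number a weaker inhibitor of growth:

- Compound 1 `COC(=O)[C@@]1(C)CC[C@@H]2C3=C1CC[C@@H](C)[C@]3(C)C[C@@H]1c3ccccc3N[C@H]21` gives 78000 nM
- Compound 2 `COC(=O)[C@@]1(C)CC[C@@H]2C3=C1CC[C@@H](C)[C@]3(C)C[C@@H]1c3cc(C)ccc3N[C@H]21` gives 15000 nM
- Compound 3 `COC(=O)[C@@]1(C)CC[C@@H]2C3=C1CC[C@@H](C)[C@]3(C)C[C@@H]1c3cc(Cl)ccc3N[C@H]21` gives 28000 nM

Compound 3 stands second highest of the three numbers. Its nearest neighbour is compound 2, and the step of a 1.9-fold higher number from compound 2 to compound 3 (0.27 log units; within the scatter) lies within the usual scatter, so the two cannot be ranked. Its furthest neighbour is compound 1, and the step of a 2.8-fold lower number from compound 1 to compound 3 (0.44 log units; beyond the scatter) is beyond the scatter.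

Compound 4 `COC(=O)[C@@]1(C)CC[C@@H]2C3=C1CC[C@@H](C)[C@]3(C)C[C@@H]1c3cc(OC)ccc3N[C@H]21` is the next compound to be tested. It differs from compound 3 in one place: methoxy in place of chloro on an aromatic carbon.

Among the compounds with values here, no measured pair swaps chloro for methoxy, so the expectation rests on neighbouring steps. Both a 5.2-fold lower number from compound 1 to compound 2 (0.72 log units; beyond the scatter) and a 2.8-fold lower number from compound 1 to compound 3 (0.44 log units; beyond the scatter) show that placing a group on this aromatic carbon gave a lower number than hydrogen, while a 1.9-fold higher number from compound 2 to compound 3 (0.27 log units; within the scatter) shows that the two groups tried there gave numbers within the scatter of each other. A third group at the same spot is therefore expected to land near compound 3, with a step of a 1.3-fold lower number from compound 3 to compound 4 (0.10 log units; within the scatter) that stays within the scatter. Compound 4 is estimated at 22000 nM, in the range 8000 nM to 60000 nM.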

Compound 4, concentration for 50% growth inhibition: 15000 nM
Compound 4: the middle estimate sits 1.5-fold (0.17 log units) above what was measured; measured number inside the range.
By their numbers in this assay, from the lowest: compounds 2, 4 and 3 (each within the scatter of the next); then compound 1.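

With methoxy, a third group on this aromatic carbon gives a 5.2-fold lower number from compound 1 to compound 4 (0.72 log units; beyond the scatter) in this assay, so all three groups shown at this spot now have lower numbers than hydrogen. The three groups cannot be ranked against one another: a 1.9-fold lower number from compound 3 to compound 4 (0.27 log units; within the scatter) and no change at the digits printed from compound 2 to compound 4 (within the scatter) both lie within the scatter, even though methoxy has one hydrogen-bond acceptor and chloro has none. No measurement at hand bears on what lies behind this result.

The groups shown here are methyl, chloro and methoxy, so it remains open whether an amine or a carboxylic acid at this spot would follow the same trend. Also open, from the compounds shown here alone, is whether any of these groups on another carbon of this ring would give a lower number than hydrogen.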